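Moving the fluorine on the phenoxy group of a coumarin-like series

The compounds below may be only part of what the source reports. "The series", "measured", "known", "first", "only" and "open" are said of these compounds alone.

Three compounds built on a shared core carry a piperidine carboxamide linked through a three-carbon chain to an aryl ether. Compound 1 `Cc1c(Cc2ccc(Cl)cc2)c(=O)oc2cc(OCC(O)CN3CCC(C(N)=O)CC3)ccc12` bears a chlorine on its benzyl ring and gives 40000 nM in an ADME assay on A549 cells (Homo sapiens) for cytotoxicity, read by CellTiter-Glo; on this read-out higher numbers stand for lower toxicity in this test and lower numbers for higher toxicity in this test. Going by the values given here, compound 2 `COc1ccccc1-c1ccc(Cc2c(C)c3ccc(OCC(O)CN4CCC(C(N)=O)CC4)cc3oc2=O)cc1` gives 91600 nM; the change a 2.3-fold higher number from compound 1 to compound 2 (0.36 log units; beyond the scatter) is the only single-point step among the measured compounds. Compound 3 `Cc1c(Cc2ccccc2)c(=O)oc2cc(OCC(CN3CCC(C(N)=O)CC3)Oc3ccccc3F)ccc12` adds a 2-fluorophenoxy group on the chain and gives 79600 nM, the second highest of the three numbers, within the scatter of both compound 2 and compound 1.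

Compound 4 `Cc1c(Cc2ccccc2)c(=O)oc2cc(OCC(CN3CCC(C(N)=O)CC3)Oc3ccc(F)cc3)ccc12` differs from compound 3 only in the position of the fluorine: 4-fluorophenyl in place of 2-fluorophenyl on an oxygen on a saturated carbon. Among the compounds with values here, no measured step touches this part of the molecule; the one step that exists concerns the benzyl ring, not the phenoxy group, so it gives no guidance on the direction of this change. The three measured values are all within the scatter of one another, and nothing in the data suggests that shifting the fluorine should move the number beyond that scatter.

Compound 4 is therefore expected to show a 1.0-fold higher number from compound 3 to compound 4 (0.00 log units; within the scatter), with an estimated value of 80000 nM and a likely range from 40000 nM to 160000 nM.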

Compound 4, half-maximal cytotoxic concentration: 66400 nM
The estimate for compound 4 lay 1.2-fold (0.08 log units) above the measured number; low and high end bracket the measured number.
By their numbers in this assay, from the lowest: compounds 1, 4, 3 and 2 (each within the scatter of the next, the first and the last beyond it).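

Going by these compounds alone, compound 3 and compound 4 carry the same atoms and differ only in where the fluorine sits, so this pair gives the first direct reading on the phenoxy group. In this assay, within the data shown here, 4-fluorophenyl in place of 2-fluorophenyl on an oxygen on a saturated carbon gives a 1.2-fold lower number from compound 3 to compound 4 (0.08 log units; within the scatter), and the two placings of the fluorine cannot be told apart on this read-out, whereas the only earlier step, on the benzyl ring, gave a 2.3-fold higher number from compound 1 to compound 2 (0.36 log units; beyond the scatter) and lay beyond the scatter. No independent measurement is available to explain this result.

The compounds shown contain no pair that differs only in having the substituted phenoxy group on the chain rather than the hydroxyl group of compound 1 and compound 2, so what the phenoxy group itself contributes stays open. Also open, going by these compounds, is whether the insensitivity seen with fluorine would hold for a different group on that ring, such as a nitrile, an amine or a carboxylic acid, since both compounds that carry the ring have fluorine on it.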